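Hydroxy Added to a Benzyl Arm of a Pyroglutamide Amidine

The source may report more compounds than this note shows. Statements on the series, on what has been measured and on what is new or still open speak of the compounds shown alone.

Compound 1 `N=C(NCc1ccccc1)[C@@H]1CCC(=O)N1Cc1ccccc1[N+](=O)[O-]` and compound 2 `N=C(NCc1ccc(O)cc1)[C@@H]1CCC(=O)N1Cc1ccccc1[N+](=O)[O-]` share one core; compound 3 `COc1ccc(CN2C(=O)CC[C@H]2C(=N)NCc2ccccc2)cc1` carries a different core, and the difference between the two cores is not broken down here. In a functional assay on SH-SY5Y cells (Homo sapiens) for cytotoxicity, read by MTT assay, with stated times of 8 h, 30 min and 12 h, tested at 0.05 uM (on this read-out higher numbers stand for a stronger effect at the one concentration tested and lower numbers for a weaker effect), compound 1 gives 10.1%, and compound 2 gives 20%. The change between them, (hydroxy in place of hydrogen on an aromatic carbon), made a step of a number 9.9 percentage points higher from compound 1 to compound 2 (within the scatter). In this assay compound 3 gives 12.3%. Compound 4 `COc1ccc(CN2C(=O)CC[C@H]2C(=N)NCc2ccc(O)cc2)cc1` is not yet measured; it differs from compound 3 by hydroxy in place of hydrogen on an aromatic carbon, the same kind of change at the same kind of place as before. A step of comparable size is expected, because the earlier step of a number 9.9 percentage points higher from compound 1 to compound 2 (within the scatter) stayed within the scatter, so the estimated step is a number 8.7 percentage points higher from compound 3 to compound 4 (within the scatter). Compound 4 is expected to give about 21%, between 10% and 32%.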

Compound 4, a percentage reported as activity, at one concentration (the size of the read-out at that concentration, not a potency): 16%
Estimate against measurement, compound 4: 5 percentage points above; the measured number falls inside the stated range.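

In this assay, hydroxy in place of hydrogen on the benzyl arm gives a number 3.7 percentage points higher from compound 3 to compound 4 (within the scatter), and the two cores can be compared directly: the same change on two cores in this assay, a number 9.9 percentage points higher (within the scatter) from compound 1 to compound 2 and a number 3.7 percentage points higher (within the scatter) from compound 3 to compound 4, 6.2 percentage points apart, within the scatter of two such steps. The change therefore shows no measurable dependence on the core, but neither step exceeds the scatter, so this does not show that the hydroxy has a real effect on either core. The step between the two cores that carry the hydroxy, a number 4 percentage points lower from compound 2 to compound 4 (within the scatter), also stays within the scatter, so 4-methoxyphenyl and 2-nitrophenyl cannot be told apart here.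

The compounds shown leave open whether an amine or a carboxylic acid at the same place on the benzyl arm would give a step beyond the scatter. They also leave open how the effects of these compounds compare at other concentrations, as each has a reading at only one concentration.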